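Moving the Second Hydroxyl Around a Shared Core

The compounds below may be only part of what the source reports. "The series", "measured", "known", "first", "only" and "open" are said of these compounds alone.

Three measured compounds share a core in which a 4-fluorophenyl group and two hydroxyphenyl groups sit on a six-membered aromatic ring with one nitrogen. Compound 1 `Oc1ccccc1-c1cc(-c2ccc(F)cc2)cc(-c2ccccc2O)n1` carries two 2-hydroxyphenyl groups. In a functional assay on T47D cells (Homo sapiens) for inhibition (on this read-out lower numbers stand for stronger inhibition and higher numbers for weaker inhibition), compound 1 reaches only the limit of > 50000 nM. Compound 2 `Oc1cccc(-c2cc(-c3ccc(F)cc3)cc(-c3ccccc3O)n2)c1` carries one 2-hydroxyphenyl and one 3-hydroxyphenyl group. In this assay compound 2 also reaches only the limit of > 50000 nM. Compound 3 `Oc1ccc(-c2cc(-c3ccc(F)cc3)cc(-c3ccccc3O)n2)cc1` carries one 2-hydroxyphenyl and one 4-hydroxyphenyl group. In this assay compound 3 likewise reaches only the limit of > 50000 nM. Compound 2 thus stands exactly where the others stand, at the limit of > 50000 nM in this assay, at which 3 of the 3 values shown sit, with no number to rank it by. The steps a step that the two limits leave unreadable from compound 1 to compound 2, a step that the two limits leave unreadable from compound 1 to compound 3 and a step that the two limits leave unreadable from compound 2 to compound 3 are all unreadable for this reason. Compound 4 `Oc1cccc(-c2cc(-c3ccc(F)cc3)cc(-c3cccc(O)c3)n2)c1` differs from compound 2 by 3-hydroxyphenyl in place of 2-hydroxyphenyl on an aromatic carbon. Because moving the hydroxyl around one ring gave only the unreadable step that the two limits leave unreadable from compound 1 to compound 2, the same move on the second ring is expected to yield a limit again. Compound 4 is therefore expected at 100000 nM, between 30000 nM and 500000 nM. The expected step that the limit leaves unreadable from compound 2 to compound 4 is essentially none.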

Compound 4, half-maximal inhibitory concentration: 6870 nM
Compound 4: the middle estimate sits 15-fold (1.16 log units) above what was measured; the measured number lies below the stated range.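

In this assay, within the data shown here, placing 3-hydroxyphenyl instead of 2-hydroxyphenyl on the aromatic carbon next to the ring nitrogen gives the first step that can be read, since the steps among compound 1, compound 2 and compound 3 cannot: an at least 7.2-fold lower number from compound 2 to compound 4 (0.86 log units; beyond the scatter). The position therefore responds to where the hydroxyl sits on the ring, at least when a 3-hydroxyphenyl group is already present on the shared core. Among the compounds shown, compound 4 alone carries no 2-hydroxyphenyl group, and it alone gives a number rather than a limit: the limit of > 50000 nM in this assay, at which 3 of the 4 values shown sit.

On these data alone, what remains open is whether the loss of the 2-hydroxyphenyl group or the presence of two 3-hydroxyphenyl groups matters more. As far as these compounds go, it is also open how an amine or a carboxylic acid in place of either hydroxyl would read.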